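This account rests on a few compounds, and the source may have more. Where it says the series, first, only, none or still open, it means among the compounds named here.

Measured so far:
compound 1 `COc1ccccc1C1C(C#N)=C(N)N(c2ccc(S(N)(=O)=O)cc2)C2=C1CCCC2` – 100%
compound 2 `COc1ccc2ccccc2c1C1C(C#N)=C(N)N(c2ccc(S(N)(=O)=O)cc2)C2=C1CCCC2` – 50%

In a functional assay on Ehrlich cells (Mus musculus) for cytotoxicity, read by trypan blue exclusion, with a stated time of 2 h, tested at 100 ug/mL (a higher number here means a stronger effect of the compound at the concentration tested, a lower number a weaker effect), compound 1 gives 100%, the highest of the two numbers shown. Compound 2 gives 50%, lower by a margin beyond the usual scatter. Compound 3 `N#CC1=C(N)N(c2ccc(S(N)(=O)=O)cc2)C2=C(CCCC2)C1c1cccs1` has not yet been measured. It differs from compound 1 in one place: thiophen-2-yl in place of 2-methoxyphenyl on a saturated ring carbon. Among the compounds with values here, no measured pair mirrors this change, so its size is uncertain; a modest fall in this assay is expected rather than none. The expected step is a number 30 percentage points lower from compound 1 to compound 3 (beyond the scatter). Compound 3 is estimated to give about 70%, within a range from 35% to 100%.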

Compound 3, a percentage reported as activity, at one concentration (the size of the read-out at that concentration, not a potency): 20%
Compound 3: the middle estimate sits 50 percentage points above what was measured; measured number below the stated range.
By their numbers in this assay, from the lowest: compound 3; then compound 2; then compound 1.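

In this assay the group on the saturated ring carbon proves decisive for the shared core: thiophen-2-yl in place of 2-methoxyphenyl gives a number 80 percentage points lower from compound 1 to compound 3 (beyond the scatter). Most of the effect seen with the six-membered aromatic ring is thus lost with the five-membered one. Nothing measured here explains the size of this step. The change alters the ring and removes the methoxy group together, so the two cannot be told apart. An unsubstituted phenyl, a furan-2-yl or a pyridin-2-yl on this carbon would leave that question open no longer.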